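This account rests on a few compounds, and the source may have more. Where it says the series, first, only, none or still open, it means among the compounds named here.

In a functional assay on FM3A cells (Mus musculus) for cytotoxicity (on this read-out lower numbers stand for an effect already at smaller amounts and higher numbers for an effect only at larger amounts of compound), compound 1 `C=C(C)COOC1(OOCC(=C)C)CCCCCCCCCCC1` gives 38000 nM, while compound 2 `C=C(C)COOC1(OOC)CCCCCCCCCCC1` gives 17000 nM, the lower of these two numbers. For the measured compounds named here, only one measured step connects them, a 2.2-fold lower number from compound 1 to compound 2 (0.35 log units; beyond the scatter), and it is modest. In that step, hydrogen replaces 1-methylethenyl on a saturated chain carbon.

Compound 3 `CCOC(C)OOC1(OOC)CCCCCCCCCCC1` differs from compound 2 in a single place: 1-ethoxyethyl in place of 2-methylprop-2-en-1-yl on an oxygen. Here 1-ethoxyethyl sits where 2-methylprop-2-en-1-yl stood, on an oxygen whose other neighbours are: oxygen. Going by the values given here, the measured step also altered a 2-methylprop-2-en-1-yl group, so it is the closest guide available, but no measured compound carries 1-ethoxyethyl. Neither the size nor the direction of the new step can therefore be read directly from the data, and no change beyond the scatter is expected. The expected result is a 1.2-fold higher number from compound 2 to compound 3 (0.07 log units; within the scatter). For compound 3, the estimate is 20000 nM, with an expected range from 7000 nM to 50000 nM.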

Compound 3, half-maximal effective concentration: 12000 nM
Compound 3: the middle estimate sits 1.7-fold (0.22 log units) above what was measured; low and high end bracket the measured number.
By their numbers in this assay, from the lowest: compounds 3 and 2 (each within the scatter of the next); then compound 1.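

In this assay, putting 1-ethoxyethyl in place of 2-methylprop-2-en-1-yl on an oxygen whose other neighbours are: oxygen gives a 1.4-fold lower number from compound 2 to compound 3 (0.15 log units; within the scatter), so the two compounds cannot be told apart on this read-out. For the compounds shown here, this is the first look at a change on this oxygen, and it shows that the group can lose its double bond and gain an oxygen, a hydrogen-bond acceptor, with no shift beyond the scatter. Compound 3 carries no 2-methylprop-2-en-1-yl group at all, yet its number stays level with that of compound 2, and nothing available here offers an explanation for this.

As far as these compounds go, it remains open whether an amine, a carboxylic acid or a longer chain on this oxygen would shift the number beyond the scatter. One swap also cannot show whether other groups at this place would behave the same way.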